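Swapping 4-fluorobenzyl for 4-methylphenyl on a sulfur

A few compounds are considered here, and "the series" means these few. Any claim that something is new, unique, unknown or untested is made for them only; others in the source may bear on it.

Going by the values given here, compound 3 `CN(C)c1ccc(/C=C(/SCc2ccc(F)cc2)C(=O)c2ccc(Br)cc2)cc1` gives 50000 nM in a functional assay on DU-145 cells (Homo sapiens) for inhibition, read by trypan blue exclusion, with a stated time of 96 h (a lower number here means a stronger inhibitor of growth, a higher number a weaker inhibitor of growth), the only true number so far. Compound 2 `CN(C)c1ccc(/C=C(/Sc2ccccc2Br)C(=O)c2ccc(Br)cc2)cc1` gives > 100000 nM, which is a limit of the assay and not a number.

Compound 4 `Cc1ccc(S/C(=C/c2ccc(N(C)C)cc2)C(=O)c2ccc(Br)cc2)cc1` differs from compound 3 in one group: 4-methylphenyl in place of 4-fluorobenzyl on a sulfur. Here 4-methylphenyl takes the place of 4-fluorobenzyl on a sulfur.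

Among the compounds with values here, one measured step bears on this change. It is an at least 2.0-fold lower number from compound 2 to compound 3 (0.30 log units; that floor lies within the scatter), where 4-fluorobenzyl replaced 2-bromophenyl on a sulfur, and its floor lies within the scatter. The new change runs the opposite way, from 4-fluorobenzyl back to a substituted phenyl on the sulfur. Compound 1 `Cc1ccc(S/C(=C/c2ccc(N(C)C)cc2)C(=O)c2ccc(Cl)cc2)cc1` also carries 4-methylphenyl on a sulfur and gives > 100000 nM, again a limit.

A higher number, meaning a weaker inhibitor of growth, is therefore expected, though the size of the step is poorly fixed by so little data. The expected step is a 2.0-fold higher number from compound 3 to compound 4 (0.30 log units; within the scatter), close to the scatter. The reading may well end at the limit of > 100000 nM in this assay, at which 2 of the 3 values shown sit, and give no number at all. For compound 4 the estimated value is 100000 nM, with an expected range from 40000 nM to 200000 nM.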

Compound 4, concentration for 50% growth inhibition: > 100000 nM
Compound 4: a limit, no number (the forecaster's own chance of this, stated with the estimate: 70%); the middle value sits exactly at the limit.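

In this assay, going by these compounds alone, replacing 4-fluorobenzyl with 4-methylphenyl on a sulfur gives an at least 2.0-fold higher number from compound 3 to compound 4 (0.30 log units; that floor lies within the scatter), and this is the first step that tests this change with the bromo group on the other aromatic ring kept the same. Among the four compounds shown, the three with a substituted phenyl on the sulfur, compounds 1, 2 and 4, all end at a limit, while compound 3, with 4-fluorobenzyl, alone gives a true number, a pattern with no exception here but one resting on a single number and a floor within the scatter. The steps to compound 4 from compound 2 and from compound 1 cannot be read, so nothing can be said about 4-methylphenyl against 2-bromophenyl or about bromo against chloro, because both ends of each step are limits: the limit of > 100000 nM in this assay, at which 3 of the 4 values shown sit.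

From the compounds shown here alone, it remains open whether a real gap separates compound 3 from compound 4, and whether the fluorine matters at all. A plain benzyl, a longer phenylethyl chain or a chain ending in an amine on the sulfur would each test which part of the 4-fluorobenzyl group goes with the measurable value.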